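Carbamoyl replaces aminomethyl on a shared resorcinol-bearing scaffold

This account rests on a few compounds, and the source may have more. Where it says the series, first, only, none or still open, it means among the compounds named here.

A small set of compounds shares one core and differs only in the substituent on the outer ring. Compound 1 `CCNC(=O)c1noc(-c2cc(C(C)C)c(O)cc2O)c1-c1cc(COCC(=O)O)no1` and compound 2 `CCCNCc1cc(-c2c(C(=O)NCC)noc2-c2cc(C(C)C)c(O)cc2O)on1` carry acid and amine side chains; in a functional assay on A2780 cells (Homo sapiens) for inhibition (a higher number here means a weaker inhibitor, a lower number a stronger inhibitor), compound 1 gives "not determined" (no result reported) and compound 2 gives "not determined" (no result reported). Compound 2 therefore stands without a single number, and one further entry also lacks one. Only compound 3 `C=CNCc1cc(-c2c(C(=O)NCC)noc2-c2cc(C(C)C)c(O)cc2O)on1` offers a measured value: in this assay compound 3 gives 43 nM. Compound 4 `CCNC(=O)c1noc(-c2cc(C(C)C)c(O)cc2O)c1-c1cc(C(N)=O)no1` differs from compound 2 by carbamoyl in place of (propylamino)methyl on an aromatic carbon. Within the data shown here, with no measured step to build on, any change in this assay from compound 2 to compound 4 cannot be sized, and a modest shift in either direction is as likely as none. Compound 4 is expected to give about 100 nM, in the range 20 nM to 600 nM.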

Compound 4, half-maximal inhibitory concentration: 15 nM
Compound 4: middle estimate off by 6.7-fold (0.82 log units), on the high side, and the stated range ends above it.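

At this position on the outer ring, carbamoyl in place of (vinylamino)methyl gives a 2.9-fold lower number from compound 3 to compound 4 (0.46 log units; beyond the scatter) in this assay, so an amine side chain is not needed there for inhibition in this pair. Steps from compound 1 and compound 2 cannot be read, which leaves this as the only measured comparison at this position. Nothing shown here accounts for the gain. Going by these compounds, it remains open whether a nitrile or an N-methyl carbamoyl group at the same place would match carbamoyl.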